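Taking the Chlorine off Compound 3

A few compounds are considered here, and "the series" means these few. Any claim that something is new, unique, unknown or untested is made for them only; others in the source may bear on it.

In an ADME assay on the whole organism (plasma, Rattus norvegicus, strain Han-Wistar) for protein binding, read by LC-MS, at a dose of 1 mg/kg by the intravenous route, compound 3 `C[C@@H](Oc1cc2onc(CCC(=O)O)c2cc1Cl)c1ccc(Cl)cn1` gives 99.7%, the lowest unbound fraction of the three measured compounds. Compound 1 `Cc1ccc([C@@H](C)Oc2cc3onc(CCC(=O)O)c3cc2Cl)nc1` gives 99.1%, and compound 2 `Cc1ccc([C@@H](C)Oc2cc3onc(CCC(=O)O)c3cc2Cl)nn1` gives 93.3%. Compound 4 `C[C@@H](Oc1cc2onc(CCC(=O)O)c2cc1Cl)c1ccccn1` has hydrogen in place of chloro on an aromatic carbon. The closest guide is a 3.0-fold lower unbound fraction from compound 1 to compound 3 (0.48 log units; beyond the scatter), a modest step in which only methyl gives way to chloro. The large a 22-fold lower unbound fraction from compound 2 to compound 3 (1.35 log units; beyond the scatter) and the modest a 7.4-fold higher unbound fraction from compound 1 to compound 2 (0.87 log units; beyond the scatter) also change the ring, so they bear less directly. A modest rise in the free share is therefore expected in this assay, and the expected step is a 4.3-fold higher unbound fraction from compound 3 to compound 4 (0.64 log units; beyond the scatter). Compound 4 is estimated at 98.7%, within a range of 97% to 99.5%.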

Compound 4, plasma protein binding: 97.8%
Beside the measured number, compound 4's estimate is 1.7-fold (0.23 log units) (unbound fraction) below it; low and high end bracket the measured number.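

Taking off the chloro group gives a 7.3-fold higher unbound fraction from compound 3 to compound 4 (0.87 log units; beyond the scatter), so in this assay this one position on the pyridin-2-yl ring strongly affects how much compound stays free. Hydrogen also leaves more free than methyl, with a 2.4-fold higher unbound fraction from compound 1 to compound 4 (0.39 log units; beyond the scatter), while a 3.0-fold lower unbound fraction from compound 2 to compound 4 (0.48 log units; beyond the scatter) shows that the unsubstituted ring still does not reach the free share of the 6-methylpyridazin-3-yl compound. Nothing available explains these shifts.

From the compounds shown here alone, whether a fluoro or methoxy group here would fall within the range set by hydrogen, methyl and chloro remains open.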